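The source may report more compounds than this note shows. Statements on the series, on what has been measured and on what is new or still open speak of the compounds shown alone.

Compound 1 `COc1ccccc1-c1nnc(-c2ccc(C(=O)N/N=C/c3ccc(F)cc3)cc2)o1` gives 427000 nM in an ADME assay on THP-1 cells (Homo sapiens) for cytotoxicity; a lower number here means a stronger inhibitor, a higher number a weaker inhibitor.
Compound 2 `COc1ccccc1-c1nnc(-c2ccc(C(=O)N/N=C/c3ccc([N+](=O)[O-])cc3)cc2)o1` gives 203000 nM in this assay.
Compound 3 `COc1ccccc1-c1nnc(-c2ccc(C(=O)N/N=C/c3ccccn3)cc2)o1` gives 67000 nM in this assay.

Compound 3 stands at the lowest number of the three and is the strongest inhibitor measured here; compound 2 is nearest to it and compound 1 furthest. Compound 4 `COc1ccc(/C=N/NC(=O)c2ccc(-c3nnc(-c4ccccc4OC)o3)cc2)cc1O` differs from compound 3 in one place: 3-hydroxy-4-methoxyphenyl in place of pyridin-2-yl on a carbon with a double bond to nitrogen. Going by the values given here, two measured steps bear on this change: a 6.4-fold lower number from compound 1 to compound 3 (0.80 log units; beyond the scatter) and a 3.0-fold lower number from compound 2 to compound 3 (0.48 log units; beyond the scatter). Both move from a six-membered aromatic ring of carbon only to pyridin-2-yl, and both lower the number. Among the compounds with values here, the change to compound 4 runs the other way, back to a six-membered aromatic ring of carbon only, though one carrying groups that no measured pair covers. The expectation for compound 4 in this assay is therefore a higher number, by a step of about the size seen in those two pairs, which is expected to be a 3.0-fold higher number from compound 3 to compound 4 (0.47 log units; beyond the scatter). Compound 4 is estimated at 200000 nM, with an expected range from 70000 nM to 500000 nM.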

Compound 4, half-maximal inhibitory concentration: 260000 nM
Estimate against measurement, compound 4: 1.3-fold (0.11 log units) below; the measured number falls inside the stated range.
By their numbers in this assay, from the lowest: compound 3; then compounds 2, 4 and 1 (each within the scatter of the next, the first and the last beyond it).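

At the carbon with a double bond to nitrogen, 3-hydroxy-4-methoxyphenyl also fails to match pyridin-2-yl in this assay, with a 3.9-fold higher number from compound 3 to compound 4 (0.59 log units; beyond the scatter), so the lowest number still belongs to the only ring here containing nitrogen. The new group cannot be separated from either earlier carbon-only ring, with a 1.3-fold higher number from compound 2 to compound 4 (0.11 log units; within the scatter) and a 1.6-fold lower number from compound 1 to compound 4 (0.22 log units; within the scatter) both within the scatter, even though 4-fluorophenyl and 4-nitrophenyl are separated from each other by a 2.1-fold lower number from compound 1 to compound 2 (0.32 log units; beyond the scatter). No measurement shown here explains any of these differences.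

On these data alone, with pyridin-2-yl as the only nitrogen-containing ring, it remains open whether pyridin-3-yl or pyridin-4-yl would give a similarly low number. Also open, as far as these compounds go, is how a phenyl ring carrying an amine or a carboxylic acid, or a longer alkyl chain in place of the ring, would behave at this carbon.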